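A few compounds are considered here, and "the series" means these few. Any claim that something is new, unique, unknown or untested is made for them only; others in the source may bear on it.

Compound 1 `CCCc1cn(C(c2ccccc2)c2ccccc2)nn1` gives 11000 nM in an assay on isolated protein for inhibition of Aromatase (Homo sapiens), read by fluorescence and colorimetric assay, with a stated time of 30 min; on this read-out higher numbers stand for weaker inhibition and lower numbers for stronger inhibition.
Compound 2 `CCCCCCc1cn(C(c2ccccc2)c2ccccc2)nn1` gives 14800 nM in this assay.
Compound 3 `CCCCCCCc1cn(Cc2ccccc2)nn1` gives 9530 nM in this assay.

Compounds 1 and 2 share one core and differ in a single place: propyl in place of hydrogen on a saturated chain carbon, three bonds along the chain from an aromatic carbon. That change produced a 1.3-fold higher number from compound 1 to compound 2 (0.13 log units; within the scatter), so on this read-out the two compounds cannot be told apart. Compound 3 is built on another core; the difference between the two cores is not broken down here. Its value and those of compound 1 and compound 2 all lie within the usual scatter of one another, so the three measured compounds look much alike in this assay.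

Compound 4 `CCCCCCCCCCc1cn(Cc2ccccc2)nn1` has not yet been measured. It comes from compound 3 by propyl in place of hydrogen on a saturated chain carbon, seven bonds along the chain from an aromatic carbon. For the measured compounds named here, this is the same kind of change as the one from compound 1 to compound 2, but not the same change: in the earlier pair the propyl enters three bonds along the chain from an aromatic carbon, whereas here it enters seven bonds along the chain from an aromatic carbon, and the two cores differ. Going by the values given here, the only guide is the earlier pair, and because that pair showed a 1.3-fold higher number from compound 1 to compound 2 (0.13 log units; within the scatter), the step from compound 3 to compound 4 is expected to stay small as well, estimated at a 1.3-fold higher number from compound 3 to compound 4 (0.10 log units; within the scatter). Compound 4 is therefore estimated at 12000 nM in this assay, with the likely range running from 5000 nM to 30000 nM.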

Compound 4, half-maximal inhibitory concentration: 6400 nM
Estimate against measurement, compound 4: 1.9-fold (0.27 log units) above; the range from low to high includes it.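

In this assay, propyl in place of hydrogen on a saturated chain carbon, seven bonds along the chain from an aromatic carbon, gives a 1.5-fold lower number from compound 3 to compound 4 (0.17 log units; within the scatter), so compound 3 and compound 4 cannot be told apart on this read-out. Set beside the earlier pair, the change shows no difference between the two cores that stands clear of ordinary measurement noise: the same change on two cores in this assay, a 1.3-fold higher number (0.13 log units; within the scatter) from compound 1 to compound 2 and a 1.5-fold lower number (0.17 log units; within the scatter) from compound 3 to compound 4, 2.0-fold (0.30 log units) apart, within the scatter of two such steps This suggests that, in these two pairs, lengthening the chain by propyl leaves the number within the scatter on either core, but it does not show that the change is without effect in general or that it would behave alike on a further core, since there are only two pairs, and the propyl enters three bonds along the chain in one and seven bonds along the chain in the other.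

All the compounds shown carry a plain saturated chain, so it remains open whether an amine or a carboxylic acid at the end of that chain, or a much longer chain, would give a step that stands beyond the scatter. How much of any difference comes from the two cores themselves also stays open, as no pair shown isolates it.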